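A Nitrile in Place of Fluorine on the Outer Ring

The source may hold more compounds than are shown below. What is called first, only, known or untested is meant among the compounds shown, and "the series" means these compounds.

Two compounds have so far been run through an in vitro functional assay on HEK293 cells for antagonist activity at melanin-concentrating hormone receptor 1 (Homo sapiens); on this read-out higher numbers stand for larger maximal responses and lower numbers for smaller maximal responses. Compound 1 `Cc1ccc(CN2CCC(NC(=O)NCc3ccc(-c4ccccc4)cc3)CC2)cc1` ends in a plain biphenyl; in this assay compound 1 reaches 124%. Compound 2 `Cc1ccc(CN2CCC(CCN(Cc3ccc(-c4ccc(F)cc4)cc3)C(=O)NC(C)C)CC2)cc1` has a longer link, a branched urea and a 4-fluorophenyl at the far end; in this assay compound 2 reaches 113%. Of the two numbers, compound 2 is the lower one, and its gap to compound 1 lies beyond the usual scatter of repeated measurements. The two structures differ in several places at once. No single structural step can be read off between them.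

Compound 3 `Cc1ccc(CN2CCC(CCN(Cc3ccc(-c4cccc(C#N)c4)cc3)C(=O)NC(C)C)CC2)cc1` keeps everything of compound 2 except the outer ring. The difference is 3-cyanophenyl in place of 4-fluorophenyl on an aromatic carbon. For the measured compounds named here, no measured pair shows what such a swap does to the largest response, so the expectation rests on the single value of compound 2 and on caution. The change is expected to shift the largest response by a number 3 percentage points lower from compound 2 to compound 3 (within the scatter), a step that stays within the scatter rather than beyond it. Compound 3 is therefore estimated to reach 110%, with a plausible range from 95% to 128%.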

Compound 3, largest response reached (reported as Imax), in percent of the reference or control that the assay uses: 97%
Compound 3: the middle estimate sits 13 percentage points above what was measured, within the range that was stated.
By their numbers in this assay, from the lowest: compound 3; then compound 2; then compound 1.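

In this assay, for the compounds shown here, the outer ring is the first place where a single change can be read, and the change is not silent: putting 3-cyanophenyl in place of 4-fluorophenyl gives a number 16 percentage points lower from compound 2 to compound 3 (beyond the scatter). The rest of the molecule is the same in both compounds, so this step belongs to the outer ring alone, which sits on an aromatic carbon para to a large group, and shows that the largest response depends on what that ring carries. The entering group brings a nitrile with one hydrogen-bond acceptor, where the leaving group has none, but nothing available here bears on what lies behind the step, which therefore stands as an observation only.

The swap changes both the group and its place on the ring, so the compounds shown cannot separate the effect of the nitrile from that of its position. Also open, from the compounds shown here alone, are how a methoxy group or an amine on the same outer ring would read out, and whether this step would carry over to the shorter link and plain urea of compound 1.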